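Series notes: the step from compound 2 to compound 3

The source may hold more compounds than are shown below. What is called first, only, known or untested is meant among the compounds shown, and "the series" means these compounds.

Measured so far:
compound 1 `CC(Sc1nc2c(cnn2C)c(=O)n1-c1ccc(CN)cc1)c1ccccc1` — 64%
compound 2 `COCCc1ccc(-n2c(SC(C)c3ccccc3)nc3c(cnn3C)c2=O)cc1` — 54%

In an assay on isolated protein for inhibition of retinal dehydrogenase 2 (Homo sapiens), tested at 5 uM (a lower number here means less inhibition, a higher number more inhibition at the concentration tested (going by the name of the read-out)), compound 2 gives 54%, the lower of the two numbers; compound 1 gives 64%, and the step of a number 10 percentage points lower from compound 1 to compound 2 (within the scatter) lies within the scatter. Compound 3 `CC(Sc1nc2c(cnn2C)c(=O)n1-c1ccc(CN(C)C)cc1)c1ccccc1` differs from compound 2 by dimethylamino in place of methoxymethyl on a saturated chain carbon bound to an aromatic carbon. Within the data shown here, the only step bearing on this, amino to methoxymethyl at the same place, was a number 10 percentage points lower from compound 1 to compound 2 (within the scatter) and so small that no movement beyond the scatter is expected. The expected step is a number 6 percentage points higher from compound 2 to compound 3 (within the scatter). Compound 3 is estimated at 60%, in the range 45% to 75%.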

Compound 3, a percentage reported as inhibition, at one concentration (the size of the read-out at that concentration, not a potency): 86%
Estimate against measurement, compound 3: 26 percentage points below, outside the stated range (above it).
By their numbers in this assay, from the lowest: compounds 2 and 1 (each within the scatter of the next); then compound 3.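

The position on a saturated chain carbon bound to an aromatic carbon responds to the group in this assay: dimethylamino gives a number 32 percentage points higher from compound 2 to compound 3 (beyond the scatter) when it replaces methoxymethyl and a number 22 percentage points higher from compound 1 to compound 3 (beyond the scatter) when it replaces amino, whereas amino and methoxymethyl alone had stayed within the scatter. Dimethylamino and methoxymethyl match in heavy atoms, donors and acceptors, with nitrogen in place of oxygen. Nothing on hand accounts for this step.

Open, as far as these compounds go, is whether both methyl groups are needed, which methylamino would address. Diethylamino, pyrrolidine or a carboxylic acid at this place would show how far the change extends.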